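The compounds below may be only part of what the source reports. "The series", "measured", "known", "first", "only" and "open" are said of these compounds alone.

Compound 1 `COc1ccc(-c2cc3ccc(OC)cc3nc2Nc2ccc(NC(=O)CN3CCCC3)cc2)cc1` and compound 2 `COc1ccc(-c2cc3ccc(OC)cc3nc2Nc2ccc(NC(=O)CN3CCCCC3)cc2)cc1` share one core and differ only in the amide tail, where (piperidin-1-yl in place of pyrrolidin-1-yl on a saturated chain carbon bound to a carbonyl carbon). In a functional assay on HUVEC cells (Homo sapiens) for antiproliferative activity, read by MTT assay, with a stated time of 48 h (on this read-out higher numbers stand for weaker inhibition and lower numbers for stronger inhibition), compound 1 gives 8600 nM, while compound 2 gives 23500 nM, so that change made a 2.7-fold higher number from compound 1 to compound 2 (0.44 log units; beyond the scatter). Compound 3 `COc1ccc(-c2cc3cc(OC)ccc3nc2Nc2ccc(NC(=O)CN3CCCC3)cc2)cc1` carries the same tail as compound 1 on a differently built core; the difference between the two cores is not broken down here. In this assay compound 3 gives 13100 nM, and this value and those of compound 1 and compound 2 all lie close to one another. Compound 4 `COc1ccc(-c2cc3cc(OC)ccc3nc2Nc2ccc(NC(=O)CN3CCCCC3)cc2)cc1` repeats the same change on the core of compound 3: piperidin-1-yl in place of pyrrolidin-1-yl on a saturated chain carbon bound to a carbonyl carbon. Because the earlier step was a 2.7-fold higher number from compound 1 to compound 2 (0.44 log units; beyond the scatter), a step of similar size is expected here, a 2.5-fold higher number from compound 3 to compound 4 (0.40 log units; beyond the scatter). Compound 4 is accordingly expected to give about 33000 nM, with a likely range from 15000 nM to 75000 nM.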

Compound 4, half-maximal inhibitory concentration: > 50000 nM
Compound 4: no number, only a limit; the forecaster's own chance of this, stated with the estimate: 15%; middle value at least 1.5-fold (0.18 log units) away from the limit.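

For compound 4, > 50000 nM is a limit of the assay and not a number. Even so, piperidin-1-yl in place of pyrrolidin-1-yl gives an at least 3.8-fold higher number from compound 3 to compound 4 (0.58 log units; beyond the scatter) in this assay, so on both cores shown the change goes with weaker inhibition, and its direction carries over from one core to the other. Whether its size also carries over cannot be read from these two steps: the same change on two cores in this assay, a 2.7-fold higher number (0.44 log units; beyond the scatter) from compound 1 to compound 2 and an at least 3.8-fold higher number (0.58 log units; beyond the scatter) from compound 3 to compound 4; the limit leaves it open whether they differ

Going by these compounds, what a morpholin-4-yl ring or an open-chain dimethylamino group would do in the same place on the tail stays open. So does whether the change would point the same way on any third core.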